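Pyridin-2-yl in Place of a Trifluoromethylphenyl Group

This account rests on a few compounds, and the source may have more. Where it says the series, first, only, none or still open, it means among the compounds named here.

Three measured compounds share one core and differ only in the aromatic group attached to an amine nitrogen in a ring. Compound 1 `CCCc1nc(-c2ccccc2)c(CNCCN2CCN(c3ccc(C)cc3)CC2)o1` gives 48.1% in an assay on HEK293 cells for inhibition of Voltage-dependent T-type calcium channel subunit alpha-1G (Homo sapiens), read by fluorescence, tested at 10 uM; on this read-out higher numbers stand for more inhibition at the one concentration tested (going by the name of the read-out) and lower numbers for less inhibition. Compound 2 `CCCc1nc(-c2ccccc2)c(CNCCN2CCN(c3cccc(OC)c3)CC2)o1` gives 40.2% in this assay, and compound 3 `CCCc1nc(-c2ccccc2)c(CNCCN2CCN(c3ccc(C(F)(F)F)cc3)CC2)o1` gives 58.7%. Compound 3 stands highest of the three: the step of a number 10.6 percentage points higher from compound 1 to compound 3 (beyond the scatter) and the step of a number 18.5 percentage points higher from compound 2 to compound 3 (beyond the scatter) both lie beyond the scatter, while the step of a number 7.9 percentage points lower from compound 1 to compound 2 (within the scatter) does not.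

Compound 4 `CCCc1nc(-c2ccccc2)c(CNCCN2CCN(c3ccccn3)CC2)o1` is not yet measured. Its change from compound 3 is pyridin-2-yl in place of 4-(trifluoromethyl)phenyl on an amine nitrogen in a ring. Within the data shown here, none of the measured steps brings in a ring with a hetero atom, so they bear on this change only loosely: each swaps one aromatic group on the same ring nitrogen, and together they span a spread about as large as a number 18.5 percentage points higher from compound 2 to compound 3 (beyond the scatter). Because compound 3 gives 58.7% and sits above both compound 1 and compound 2, a further swap of this group is expected to land lower rather than higher. The expected step is a number 18.7 percentage points lower from compound 3 to compound 4 (beyond the scatter). Compound 4 is therefore estimated at 40% in this assay, with a range from 22% to 58%.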

Compound 4, a percentage reported as inhibition, at one concentration (the size of the read-out at that concentration, not a potency): 48.1%
Beside the measured number, compound 4's estimate is 8.1 percentage points below it; the measured number falls inside the stated range.
By their numbers in this assay, from the lowest: compounds 2, 1 and 4 (each within the scatter of the next); then compound 3.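

Among these compounds, this change puts a ring with a hetero atom on the ring nitrogen for the first time, and in this assay pyridin-2-yl does not match 4-(trifluoromethyl)phenyl (a number 10.6 percentage points lower from compound 3 to compound 4 (beyond the scatter)). Set against the other two aromatic groups, pyridin-2-yl cannot be told apart from 3-methoxyphenyl (a number 7.9 percentage points higher from compound 2 to compound 4 (within the scatter)) or from 4-methylphenyl (no change at the digits printed from compound 1 to compound 4 (within the scatter)), so a ring with 1 hetero atom and 1 hydrogen-bond acceptor, and with fewer heavy atoms than 4-(trifluoromethyl)phenyl, fits within the range of the carbon-only rings with a methyl or methoxy group. Compound 3 now stands apart from all three other compounds by steps beyond the scatter, while those three sit within the scatter of their neighbours, and nothing shown explains this.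

The compounds shown leave open what an unsubstituted phenyl, a pyridin-4-yl or a pyrimidin-2-yl group would give on this same ring nitrogen, and so whether the ring nitrogen of pyridin-2-yl matters at all. They also leave open whether a trifluoromethyl group on the pyridine ring itself would bring the number back up to that of compound 3 (58.7%).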